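Trimming the cyclohexyl group of compound 1

The compounds below may be only part of what the source reports. "The series", "measured", "known", "first", "only" and "open" are said of these compounds alone.

Measured so far in a functional assay on M21 cells (Homo sapiens) for antiproliferative activity, read by sulforhodamine B assay, with a stated time of 48 h; a lower number here means a stronger inhibitor, a higher number a weaker inhibitor:

- compound 1 `O=C1NCCN1c1ccc(S(=O)(=O)Nc2ccc(C3CCCCC3)cc2)cc1` gives > 1000 nM
- compound 2 `Cc1ccc(NS(=O)(=O)c2ccc(N3CCNC3=O)cc2)cc1` gives 260 nM
- compound 3 `O=C1NCCN1c1ccc(S(=O)(=O)Nc2ccc(F)cc2)cc1` gives 230 nM

Compound 1 stands at the limit of > 1000 nM in this assay, at which 1 of the 3 values shown sits, and this is a limit rather than a number. Compound 4 `CCc1ccc(NS(=O)(=O)c2ccc(N3CCNC3=O)cc2)cc1`, not yet measured, has ethyl in place of cyclohexyl on an aromatic carbon, para to a large group: ethyl in place of cyclohexyl on an aromatic carbon. Two measured replacements of the cyclohexyl group bear on this change. With methyl the result is an at least 3.8-fold lower number from compound 1 to compound 2 (0.58 log units; beyond the scatter), and with fluoro it is an at least 4.3-fold lower number from compound 1 to compound 3 (0.63 log units; beyond the scatter). Between these two smaller groups the result is a 1.1-fold lower number from compound 2 to compound 3 (0.05 log units; within the scatter). Compound 4 is therefore expected to resemble compound 2 260 nM, giving an expected at least 3.3-fold lower number from compound 1 to compound 4 (0.52 log units; beyond the scatter). For compound 4 the estimated value is 300 nM, with an expected range from 130 nM to 700 nM.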

Compound 4, half-maximal inhibitory concentration: 480 nM
Beside the measured number, compound 4's estimate is 1.6-fold (0.20 log units) below it; low and high end bracket the measured number.
By their numbers in this assay, from the lowest: compounds 3, 2 and 4 (each within the scatter of the next, the first and the last beyond it). At a limit, above all of these: compound 1.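

In this assay, ethyl in place of the cyclohexyl group still gives a measured number, with an at least 2.0-fold lower number from compound 1 to compound 4 (0.31 log units; beyond the scatter). Ethyl stays within the scatter of methyl, with a 1.8-fold higher number from compound 2 to compound 4 (0.27 log units; within the scatter), yet it separates from fluoro, with a 2.1-fold higher number from compound 3 to compound 4 (0.32 log units; beyond the scatter), a gap that methyl and fluoro did not show between themselves. Compound 1 remains a limit and not a number: the limit of > 1000 nM in this assay, at which 1 of the 4 values shown sits.

As far as these compounds go, what a propyl chain, a methoxy group or an amine would give on this aromatic carbon stays open. From the compounds shown here alone, the full size of the steps away from compound 1 also stays open.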